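Working notes: from an aldehyde to an expected enone analogue

The compounds below may be only part of what the source reports. "The series", "measured", "known", "first", "only" and "open" are said of these compounds alone.

Of the compounds shown here, two have numbers so far. Compound 1 `CCOC(=O)c1cc2cc(/C=C/C(=O)c3ccc(C)cc3)cc(C(C)CC)c2oc1=O` gives in a functional assay on MCF7 cells (Homo sapiens) for cytotoxicity, read by sulforhodamine B assay, with a stated time of 48 h (a lower number here means a stronger inhibitor, a higher number a weaker inhibitor), a value of 81100 nM. Compound 2 `CCOC(=O)c1cc2cc(C=O)cc(C(C)CC)c2oc1=O` gives in this assay a value of 113000 nM, the higher of the two numbers, though its gap to compound 1 lies within the scatter. Compound 3 `CCOC(=O)c1cc2cc(/C=C/C(=O)c3ccccc3)cc(C(C)CC)c2oc1=O` has not been measured; it differs from compound 2 by 2-benzoylethenyl in place of formyl on an aromatic carbon. Going by the values given here, no step between measured compounds covers this change. Compound 3 is expected to land near compound 1, whose structure is close and whose value in this assay is 81100 nM. The step of a 1.4-fold lower number from compound 2 to compound 3 (0.15 log units; within the scatter) is therefore expected to stay within the scatter. Compound 3 is estimated at 80000 nM, with a range from 40000 nM to 160000 nM.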

Compound 3, half-maximal inhibitory concentration: 88100 nM
The estimate for compound 3 lay 1.1-fold (0.04 log units) below the measured number; low and high end bracket the measured number.
By their numbers in this assay, from the lowest: compounds 1, 3 and 2 (each within the scatter of the next).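

In this assay, 2-benzoylethenyl in place of formyl on this aromatic carbon gives a 1.3-fold lower number from compound 2 to compound 3 (0.11 log units; within the scatter) and so adds a six-membered aromatic ring without a step beyond the scatter. Hydrogen in place of methyl on an aromatic carbon gives a 1.1-fold higher number from compound 1 to compound 3 (0.04 log units; within the scatter) and likewise leaves the number within the scatter. No supporting data account for either step. Going by these compounds, whether an amine or a carboxylic acid in place of formyl would move the number beyond the scatter stays open, and so does the effect of replacing the sec-butyl group.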